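The compounds below may be only part of what the source reports. "The series", "measured", "known", "first", "only" and "open" are said of these compounds alone.

Of the compounds shown here, three built on the same core have been tested in a functional assay on the whole organism (strain Wistar) for inhibition, with Rattus norvegicus as the target, read by paw edema, with stated times of 1 h and 4 h, at a dose of 10 mg/kg by the intraperitoneal route; a higher number here means more inhibition at the dose given (going by the name of the read-out), a lower number less inhibition. Compound 1 `COc1cc(/C=C/C(=O)/C=C(O)/C=C/c2ccc(OC(=O)[C@@H](CCSC)NC(=O)OCc3ccccc3)c(OC)c2)ccc1OC(=O)[C@@H](CCSC)NC(=O)OCc1ccccc1` gives 108%. Compound 2 `COc1cc(/C=C/C(=O)/C=C(O)/C=C/c2ccc(OC(=O)CNC(=O)OCc3ccccc3)c(OC)c2)ccc1OC(=O)CNC(=O)OCc1ccccc1` gives 39%. Compound 3 `COc1cc(/C=C/C(=O)/C=C(O)/C=C/c2ccc(OC(=O)C(C)NC(=O)OCc3ccccc3)c(OC)c2)ccc1OC(=O)C(C)NC(=O)OCc1ccccc1` gives 115%. On these numbers compound 3 and compound 1 sit close together, within the usual scatter of each other, so no order between them can be read; compound 2 lies far below both, a gap beyond the scatter.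

Compound 4 `COc1cc(/C=C/C(=O)/C=C(O)/C=C/c2ccc(OC(=O)[C@H](C)NC(=O)OCc3ccccc3)c(OC)c2)ccc1OC(=O)[C@H](C)NC(=O)OCc1ccccc1` is the same molecule as compound 3 with one distinction: the two compounds have the same atoms and bonds; at least one stereo element is drawn with a configuration in one of them and without one in the other: 2 of 5 stereo elements differ; a stereocentre at a saturated chain carbon is drawn without a configuration in compound 3 and S in compound 4; a stereocentre at a saturated chain carbon is drawn without a configuration in compound 3 and S in compound 4. Nothing is added or taken away; the single methyl-bearing chain carbon in each ester is drawn in compound 4 with the S configuration that compound 3 leaves open. Compound 1, which also carries the S configuration at its chain carbons, gives 108%, close to compound 3. Among the measured compounds shown here, no pair of measured compounds separated by only this kind of change has been tested, so the size of the step is uncertain, but nothing in the set points to a move beyond the scatter in either direction.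

For compound 4 the estimate in this assay is 112%, expected to fall between 90% and 130%. This estimate means a step of a number 3 percentage points lower from compound 3 to compound 4 (within the scatter), expected to lie within the scatter.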

Compound 4, a percentage reported as inhibition, in the whole organism at one dose (the size of the read-out at that dose, not a potency): 14%
Compound 4: middle estimate off by 98 percentage points, on the high side; measured number outside the range, below it.
By their numbers in this assay, from the lowest: compound 4; then compound 2; then compounds 1 and 3 (each within the scatter of the next).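

In this assay the result is a number 101 percentage points lower from compound 3 to compound 4 (beyond the scatter), even though no atom was added or taken away. The earlier compounds shown here differ from one another in the group carried on the chain carbon of each ester, so they could not show what the configuration at that carbon does on its own; this pair holds the methyl group constant and shows that how this carbon is specified cannot be treated as a minor detail of the drawing. Only one structural distinction separates the two compounds, so the large step can be tied to stereochemistry at these two carbons and to nothing else in the structures: the fact that one of compounds 3 and 4 is drawn with a defined configuration and the other without, at the place where they differ

On these data alone, what remains open is what the undefined drawing of compound 3 stands for, whether a mixture of forms or a single form, and how a compound with the opposite configuration at both chain carbons would read. Also open, as far as these compounds go, is whether configuration at this carbon matters as much when the methyl group is replaced by another group, such as an ethyl group or a hydroxymethyl group.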